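Hydrazone arms on a thiosemicarbazide core: cell growth inhibition

The source may report more compounds than this note shows. Statements on the series, on what has been measured and on what is new or still open speak of the compounds shown alone.

Measured compounds:
Compound 1, `CC1=CC[C@@H]([C@@](C)(O)CCCC(C)(C)NC(=S)NN)CC1`: in a functional assay on NCI-H460 cells (Homo sapiens) for cytotoxicity, read by sulforhodamine B assay (a lower number here means a stronger inhibitor of growth, a higher number a weaker inhibitor of growth), compound 1 gives 84000 nM.
Compound 2, `CC1=CC[C@@H]([C@@](C)(O)CCCC(C)(C)NC(=S)N/N=C\c2ccccc2[N+](=O)[O-])CC1`: in this assay compound 2 reaches only a limit of the assay, > 100000 nM.
Compound 3, `CC1=CC[C@@H]([C@@](C)(O)CCCC(C)(C)NC(=S)N/N=C\c2ccc([N+](=O)[O-])cc2)CC1`: in this assay compound 3 reaches only a limit of the assay, > 100000 nM.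

Compound 1 stands as the only one of the three with a real number; the other two sit at the limit of > 100000 nM in this assay, at which 2 of the 3 values shown sit. The step that the two limits leave unreadable from compound 2 to compound 3 runs between two limits and therefore has no readable size.

Compound 4, `CC1=CC[C@@H]([C@@](C)(O)CCCC(C)(C)NC(=S)N/N=C(/C)c2ccccc2)CC1`, differs from compound 1 by a group of 9 heavy atoms (8 carbon, 1 nitrogen; one six-membered aromatic ring of carbon only) in place of one nitrogen atom, on an amide-type nitrogen. For the measured compounds named here, no measured step matches this change directly. The nearest comparison is the arm added to the same nitrogen in compounds 2 and 3, both of which end at a limit, so no direction can be read from them. An expected step of a 1.4-fold higher number from compound 1 to compound 4 (0.15 log units; within the scatter) is therefore small, if any, and may run toward the limit. Compound 4 is expected at 120000 nM in this assay, with a range from 50000 nM to 300000 nM, and a fair chance that only a limit is reported.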

Compound 4, concentration for total growth inhibition: > 100000 nM
Compound 4: no number, only a limit; the forecaster's own chance of this, stated with the estimate: 55%; the middle value lies beyond the limit too.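

In this assay compound 4 gives > 100000 nM, which is a limit of the assay and not a number. Read against compound 1, this leaves only an at least 1.1-fold higher number from compound 1 to compound 4 (0.07 log units; that floor lies within the scatter), so putting this ring-bearing arm in place of the amino group on the amide-type nitrogen shows no stronger growth inhibition, and the true size of any weakening stays hidden. What is new is that an arm with no nitro group also ends at the limit, so none of the three arms on this nitrogen gives a real number: the limit of > 100000 nM in this assay, at which 3 of the 4 values shown sit.

Going by these compounds, whether any arm on this nitrogen can give a readable value stays open, for example one ending in a carboxylic acid or an amine in place of the aromatic ring. Also open, on these data alone, is what a shorter chain in the shared core would do to compound 1.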